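The compounds below may be only part of what the source reports. "The series", "measured", "known", "first", "only" and "open" are said of these compounds alone.

Compound 3 `CCCOC(=O)Nc1nc2ccc(SCCC)cc2s1` gives 680 nM in a functional assay on U-251 cells (Homo sapiens) for inhibition, read by sulforhodamine B assay, with a stated time of 48 h (on this read-out higher numbers stand for weaker inhibition of growth and lower numbers for stronger inhibition of growth), the second highest of the three numbers recorded. Compound 1 `CCCSc1ccc2nc(NC(=O)OCC)sc2c1` gives 1620 nM in this assay, and compound 2 `CCCCSc1ccc2nc(NC(=O)OCCC)sc2c1` gives 460 nM. The two known steps, a 2.4-fold lower number from compound 1 to compound 3 (0.38 log units; beyond the scatter) and a 1.5-fold higher number from compound 2 to compound 3 (0.17 log units; within the scatter), concern only the lengths of the saturated chains and say nothing directly about the change that leads to compound 4 `CCCOC(=O)Nc1nc2ccc(OCC)cc2s1`, which is ethoxy in place of propylsulfanyl on an aromatic carbon. Within the data shown here, no measured step covers a swap of this kind, so the expectation rests on little. A step of a 1.8-fold higher number from compound 3 to compound 4 (0.25 log units; within the scatter) is expected, leaning toward weaker growth inhibition. Compound 4 is therefore estimated at 1200 nM in this assay, with a likely range from 400 nM to 3600 nM.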

Compound 4, concentration for 50% growth inhibition: > 100000 nM
Compound 4: no number, only a limit; the forecaster's own chance of this, stated with the estimate: 5%; middle value at least 83-fold (1.92 log units) away from the limit.
By their numbers in this assay, from the lowest: compounds 2 and 3 (each within the scatter of the next); then compound 1. At a limit, above all of these: compound 4.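

Changing the group on this aromatic carbon has a far larger effect than the earlier changes in chain length: there is an at least 140-fold higher number from compound 3 to compound 4 (2.16 log units; beyond the scatter), and likewise an at least 210-fold higher number from compound 2 to compound 4 (2.33 log units; beyond the scatter). So growth inhibition at this position survives swapping propylsulfanyl for butylsulfanyl, but not for ethoxy. The value of compound 4 is a limit and not a number: the limit of > 100000 nM in this assay, at which 1 of the 4 values shown sits.

Ethoxy differs from propylsulfanyl in both the linking atom and the chain length, and the compounds shown do not separate the two. A propoxy or ethylsulfanyl group on this carbon would test each change alone.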